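The source may hold more compounds than are shown below. What is called first, only, known or untested is meant among the compounds shown, and "the series" means these compounds.

Working notes on the series

Of the compounds shown here, three have been measured in a functional assay on the whole organism for inhibition, with Rattus norvegicus as the target; on this read-out lower numbers stand for stronger inhibition and higher numbers for weaker inhibition. Compound 1 `CCCCNC(=O)C1CCc2cc(O)c(OC)cc2O1` gives 24800 nM. Compound 2 `COc1cc2c(cc1O)CCC(C(=O)NCc1ccccc1)O2` gives 21700 nM. Compound 3 `COc1cc2c(cc1O)CCC(C(=O)Nc1ccc([N+](=O)[O-])cc1)O2` gives 40100 nM. Going by the values given here, compound 1 stands second highest of the three numbers; its nearest neighbour is compound 2, and the only single-point step recorded so far, a 1.1-fold lower number from compound 1 to compound 2 (0.06 log units; within the scatter), lies within the scatter. Among the compounds with values here, no step is recorded between compound 1 and compound 3; their two values lie within the scatter of each other as well. On the numbers shown, no compound separates from the others in this assay.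

The next compound, compound 4 `COc1cc2c(cc1O)CCC(C(=O)O)O2`, differs from compound 1 in one place: hydroxy in place of butylamino on a carbonyl carbon. Within the data shown here, no measured step bears on this change. The recorded step concerns the group on a saturated chain carbon bound to an amide-type nitrogen, whereas here the butylamino group itself leaves and a hydroxy group enters on the carbonyl carbon. Among the measured compounds shown here, the only guidance is that all three variations of the carbonyl substituent measured so far sit close together, none separated beyond the scatter. For the measured compounds named here, with no comparable step to lean on, the expectation for compound 4 is loosely held, and a number close to compound 1 or somewhat higher is anticipated.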

Compound 4, half-maximal inhibitory concentration: 16800 nM
Compound 4: middle estimate off by 2.7-fold (0.43 log units), on the high side; measured number inside the range.
By their numbers in this assay, from the lowest: compounds 4, 2, 1 and 3 (each within the scatter of the next, the first and the last beyond it).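

In this assay, the exchange of butylamino for hydroxy on the carbonyl carbon gives a 1.5-fold lower number from compound 1 to compound 4 (0.17 log units; within the scatter). This extends the earlier picture: the amide nitrogen and the whole butyl chain can both leave this position without the number moving beyond the scatter, so the free carboxylic acid reads alongside the amides of compound 1 and compound 2. Variation at this carbonyl carbon now also yields the first gap beyond the scatter in the series, with compound 4 at 16800 nM and compound 3 at 40100 nM, although each remains within the scatter of its nearest neighbour in the ranking. No available measurement accounts for this result.

Going by these compounds, whether a methyl ester, a primary amide or a chain longer than butylamino on the carbonyl carbon would stay in this same range remains open. On these data alone, all four compounds share one core, so the effect of replacing its hydroxy or methoxy group with, for example, a hydrogen or an ethoxy group also remains open.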